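Isopropyl for 1-Methylethenyl: What Compound 4 Might Show

This account rests on a few compounds, and the source may have more. Where it says the series, first, only, none or still open, it means among the compounds named here.

Of the compounds shown here, three have been measured in a functional assay on MGC-803 cells (Homo sapiens) for inhibition, read by MTT assay, with a stated time of 48 h; on this read-out higher numbers stand for weaker inhibition and lower numbers for stronger inhibition. Compound 1 `COC(=O)c1cc(CNc2cc(OC)c(OC)c(OC)c2)ccc1OC` gives 49600 nM in this assay. Compound 2 `C=C(C)C(=O)N(Cc1ccc(OC)c(O)c1)c1cc(OC)c(OC)c(OC)c1` gives 390 nM, the lowest of the two numbers recorded, and the gap from compound 1 to compound 2 lies well beyond the usual scatter. Compound 3 `COc1cc(NCc2ccc(Cl)cc2)cc(OC)c1OC` returns only a limit of the assay, > 80000 nM, so no number is known for it. That reading is the limit of > 80000 nM in this assay, at which 1 of the 3 values shown sits.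

The untested compound 4 `COc1ccc(CN(C(=O)C(C)C)c2cc(OC)c(OC)c(OC)c2)cc1O` departs from compound 2 at a single site: isopropyl in place of 1-methylethenyl on a carbonyl carbon. Among the compounds with values here, no pair of measured compounds differs by this change, so the size of its effect cannot be read from the data.

The author expects a step in the weakening direction, a 3.8-fold higher number from compound 2 to compound 4 (0.59 log units; beyond the scatter), larger than the scatter but not approaching the gap seen between compound 1 and compound 2. Compound 4 is therefore estimated at 1500 nM in this assay, with a likely range from 400 nM to 6000 nM.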

Compound 4, half-maximal inhibitory concentration: 210 nM
Beside the measured number, compound 4's estimate is 7.1-fold (0.85 log units) above it; the whole stated range lies above it.
By their numbers in this assay, from the lowest: compounds 4 and 2 (each within the scatter of the next); then compound 1. At a limit, above all of these: compound 3.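

Putting isopropyl in place of 1-methylethenyl on a carbonyl carbon comes with a 1.9-fold lower number from compound 2 to compound 4 (0.27 log units; within the scatter) in this assay, so this read-out does not separate the two groups. The earlier compounds shown here held no pair that differed at this site; now one shows that the double bond of compound 2 can go without a change beyond the scatter, and compound 4 keeps the activity seen for compound 2 at this position. Nothing measured among the compounds shown accounts for this result.

Still open, on these data alone, is how much else this position accepts: whether a longer chain, a cyclopropyl ring or a chain ending in an amine on the same carbonyl carbon would read alike. The compounds shown also leave open whether the same change would behave alike on another core.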